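This account rests on a few compounds, and the source may have more. Where it says the series, first, only, none or still open, it means among the compounds named here.

Measured in a functional assay on MCF7 cells (Homo sapiens) for antiproliferative activity, read by MTT assay, with a stated time of 72 h; on this read-out lower numbers stand for stronger inhibition and higher numbers for weaker inhibition:
- compound 1 `O=C(N/N=C/c1ccc(F)cc1)Nc1ccc(Oc2ccnc3[nH]ccc23)c(F)c1`: 800 nM
- compound 2 `O=C(N/N=C/c1ccc(F)cc1Cl)Nc1ccc(Oc2ccnc3[nH]ccc23)c(F)c1`: 7610 nM

Going by the values given here, compound 2 stands highest of the two, with compound 1 as its only neighbour. The next structure, compound 3 `O=C(N/N=C/c1ccc(O)c(Br)c1)Nc1ccc(Oc2ccnc3[nH]ccc23)c(F)c1`, has 3-bromo-4-hydroxyphenyl in place of 2-chloro-4-fluorophenyl on a carbon with a double bond to nitrogen.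

Among the compounds with values here, one measured step bears on this change. Chloro in place of hydrogen gave a 9.5-fold higher number from compound 1 to compound 2 (0.98 log units; beyond the scatter), a modest step beyond the scatter. Compound 3 has no chloro, which points back towards compound 1 at 800 nM. Within the data shown here, no measured compound carries bromo or hydroxy, however, so only part of that step is expected to be recovered in this assay. The expected change is a 3.0-fold lower number from compound 2 to compound 3 (0.48 log units; beyond the scatter), towards a lower number. For compound 3 the estimate is 2500 nM, with an expected range of 600 nM to 9000 nM.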

Compound 3, half-maximal inhibitory concentration: 8230 nM
The estimate for compound 3 lay 3.3-fold (0.52 log units) below the measured number; measured number inside the range.
By their numbers in this assay, from the lowest: compound 1; then compounds 2 and 3 (each within the scatter of the next).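

In this assay, on the carbon with a double bond to nitrogen, 3-bromo-4-hydroxyphenyl in place of 2-chloro-4-fluorophenyl gives a 1.1-fold higher number from compound 2 to compound 3 (0.03 log units; within the scatter) and so leaves two aryl groups with no substituent in common indistinguishable at this position. Against 4-fluorophenyl, the same group gives a 10-fold higher number from compound 1 to compound 3 (1.01 log units; beyond the scatter) and thus leaves compound 1 alone at the low end of the three. Removing chloro therefore does not recover the number of compound 1 when bromo and hydroxy enter together. No measured evidence accounts for these results.

On these data alone, whether bromo or hydroxy carries the step from compound 1 stays open, as the two occur only together in compound 3. Also open, as far as these compounds go, is how this assay would respond to an amine or a carboxylic acid on the phenyl ring in place of fluoro.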